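A few compounds are considered here, and "the series" means these few. Any claim that something is new, unique, unknown or untested is made for them only; others in the source may bear on it.

The series shares one core, here carried by compound 1 `C=CCNC(=O)n1c(-c2ccc(OC)cc2)cc(=O)c2c(OC)cc(OC)cc21`, whose nitrogen bears an allylcarbamoyl group. In a functional assay on KOPN-8 cells (Homo sapiens) for antiproliferative activity, with a stated time of 72 h (on this read-out lower numbers stand for an effect already at smaller amounts and higher numbers for an effect only at larger amounts of compound), compound 1 gives 12000 nM. Compound 2 `COc1ccc(-c2cc(=O)c3c(OC)cc(OC)cc3n2S(=O)(=O)c2ccc(C=O)cc2)cc1` replaces that group with a (4-formylphenyl)sulfonyl group. In this assay compound 2 reaches only a limit, > 34400 nM, and not a number. The change an at least 2.8-fold higher number from compound 1 to compound 2 (0.45 log units; beyond the scatter) is therefore readable only as a lower bound. Compound 3 `COc1ccc(-c2cc(=O)c3c(OC)cc(OC)cc3n2S(=O)(=O)c2c(F)c(F)c(F)c(F)c2F)cc1` carries a 2,3,4,5,6-pentafluorophenyl on the sulfonyl sulfur. In this assay compound 3 likewise stands at a limit, > 34400 nM. Both limits sit at the same value (the limit of > 34400 nM in this assay, at which 2 of the 3 values shown sit), so the step that the two limits leave unreadable from compound 2 to compound 3 cannot be sized.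

Compound 4 `COc1ccc(-c2cc(=O)c3c(OC)cc(OC)cc3n2S(=O)(=O)c2ccc(Cl)cc2)cc1` differs from compound 3 as follows: 4-chlorophenyl in place of 2,3,4,5,6-pentafluorophenyl on a sulfonyl sulfur. Within the data shown here, the one step that bears on an aryl exchange at this sulfur, from compound 2 to compound 3, leaves its size hidden between two limits; the step from compound 1 to compound 2 shows only that a sulfonyl group at the nitrogen moves the number upward by at least a modest amount. Compound 4, as a further sulfonyl compound, is therefore expected to stay close to compound 3, with an expected step that the limit leaves unreadable from compound 3 to compound 4. For compound 4 in this assay the estimate is 40000 nM, between 15000 nM and 100000 nM, with a substantial chance that only a limit is recorded.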

Compound 4, half-maximal effective concentration: > 34400 nM
Compound 4 gave a limit, no number (the forecaster's own chance of this, stated with the estimate: 70%); the middle value is on the limit's open side.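

Exchanging allylcarbamoyl for (4-chlorophenyl)sulfonyl on the aromatic nitrogen gives an at least 2.8-fold higher number from compound 1 to compound 4 (0.45 log units; beyond the scatter), a lower bound only, and it shows that the upward move seen with compound 2 does not depend on the formyl group, since a chloro-bearing aryl group gives the same kind of result. The steps among compound 2, compound 3 and compound 4 cannot be read, so nothing can be said about how these aryl groups on the sulfonyl sulfur rank against each other. What the third sulfonyl compound adds is that three different aryl groups on this sulfur now end at one and the same limit, and not at a number: the limit of > 34400 nM in this assay, at which 3 of the 4 values shown sit.

From the compounds shown here alone, it remains open whether any group on this sulfur brings a number back into range in this assay, for instance a phenyl ring carrying an amine or a carboxylic acid, or a plain methyl in place of the aryl group. Also open, going by these compounds, is how much of the value of compound 1 rests on the allyl chain, which a shorter ethyl or a longer butyl chain on the carbamoyl group would address.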